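Aryl replacement on the core: benzofuranyl to furanyl

The compounds below may be only part of what the source reports. "The series", "measured", "known", "first", "only" and "open" are said of these compounds alone.

Within the data shown here, compound 2 `OC[C@H]1OC(n2cnc3c(-c4cc5ccccc5o4)ncnc32)[C@H](O)[C@@H]1O` stands at the higher end of the two numbers measured so far: in a functional assay on CCRF-CEM cells (Homo sapiens) for inhibition (a higher number here means a weaker inhibitor, a lower number a stronger inhibitor), compound 2 gives 15000 nM, while compound 1 `OC[C@H]1OC(n2cnc3c(-c4nccs4)ncnc32)[C@H](O)[C@@H]1O` gives 2730 nM. Among the measured compounds shown here, the single measured step, a 5.5-fold higher number from compound 1 to compound 2 (0.74 log units; beyond the scatter), describes this gap.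

Compound 3 `OC[C@H]1OC(n2cnc3c(-c4ccco4)ncnc32)[C@H](O)[C@@H]1O` differs from compound 2 in one place: furan-2-yl in place of 1-benzofuran-2-yl on an aromatic carbon. The measured step bears directly on this change. In a 5.5-fold higher number from compound 1 to compound 2 (0.74 log units; beyond the scatter), replacing a single five-membered aromatic ring at this position by a fused two-ring group was accompanied by a weaker number. Compound 3 returns to a single five-membered aromatic ring, as in compound 1, though the two ring groups are not identical, so a full return to the number of compound 1 is not assured. On this basis a step back toward the lower numbers is expected for compound 3, of a size close to a reversal of the measured step. The expected step is a 3.8-fold lower number from compound 2 to compound 3 (0.57 log units; beyond the scatter). Compound 3 is estimated at 4000 nM in this assay, with a range from 1500 nM to 12000 nM.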

Compound 3, half-maximal inhibitory concentration: 600 nM
The estimate for compound 3 lay 6.7-fold (0.82 log units) above the measured number; measured number below the stated range.
By their numbers in this assay, from the lowest: compound 3; then compound 1; then compound 2.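

In this assay, the 1-benzofuran-2-yl group and the furan-2-yl group differ only by the six-membered aromatic ring of carbon, and losing that ring gives a 25-fold lower number from compound 2 to compound 3 (1.40 log units; beyond the scatter), a larger change than a 5.5-fold higher number from compound 1 to compound 2 (0.74 log units; beyond the scatter). The earlier pair could not separate the effect of the fused ring from the exchange of the ring heteroatoms, but the series now shows that a single five-membered aromatic ring does not by itself fix the number: a 4.6-fold lower number from compound 1 to compound 3 (0.66 log units; beyond the scatter), with furan-2-yl in place of 1,3-thiazol-2-yl, so the identity of that ring also counts at this position on the shared core, and compound 3 is the strongest inhibitor of the three. Nothing available here accounts for either difference.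

Thiophen-2-yl and pyrrol-2-yl groups would show whether the number follows the single ring heteroatom of furan-2-yl or something else that separates it from 1,3-thiazol-2-yl. Going by these compounds, it also remains open whether a small addition to the furan ring, such as a methyl group or an aminomethyl group, keeps the number of compound 3 or moves it back toward that of compound 2.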